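Chain Length and Agonist Potency at the Receptor

This account rests on a few compounds, and the source may have more. Where it says the series, first, only, none or still open, it means among the compounds named here.

Compound 1 `CCCCCCCCCc1nc(O)cc(O)n1` gives 48.7 nM in a functional assay on HEK293 cells for agonist activity at G-protein coupled receptor 84 (Homo sapiens), read by calcium flux; a lower number here means that less compound is needed, a higher number that more compound is needed for the effect; compound 2 `CCCCCc1nc(O)cc(O)n1` gives 3670 nM in this assay.

Among the measured compounds shown here, compound 2 stands at the highest number of the two, and its only neighbour is compound 1, separated by the single measured step, a 75-fold higher number from compound 1 to compound 2 (1.88 log units; beyond the scatter). For the measured compounds named here, compound 3 `CCCCCCCc1nc(O)cc(O)n1` differs from compound 2 by ethyl in place of hydrogen on a saturated chain carbon, five bonds along the chain from an aromatic carbon, a smaller extension of the chain than the one separating compound 1 and compound 2, and in the opposite direction. A lower number is therefore expected for compound 3, with a step of an 8.7-fold lower number from compound 2 to compound 3 (0.94 log units; beyond the scatter) in this assay. Compound 3 is estimated at 420 nM, within a range of 150 nM to 1200 nM.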

Compound 3, half-maximal effective concentration: 12.7 nM
Beside the measured number, compound 3's estimate is 33-fold (1.52 log units) above it; measured number outside the range, below it.
By their numbers in this assay, from the lowest: compound 3; then compound 1; then compound 2.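

In this assay, among the compounds shown here, ethyl in place of hydrogen at this position gives a 290-fold lower number from compound 2 to compound 3 (2.46 log units; beyond the scatter), a larger step than the one separating compound 1 and compound 2. The number therefore does not fall steadily as the chain grows: compound 1 goes against that trend, with a 3.8-fold lower number from compound 1 to compound 3 (0.58 log units; beyond the scatter) as the chain shortens. Compound 3 thus stands lowest of the three, beyond the scatter of both others. Nothing at hand bears on what lies behind this turn. The compounds shown leave open how a longer chain, or a carboxylic acid or an amine in place of the ethyl, would read.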